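Pyrazole substitution on the shared core: compound 3 to compound 4

The source may report more compounds than this note shows. Statements on the series, on what has been measured and on what is new or still open speak of the compounds shown alone.

Compound 3 `CC(C)Oc1cc(-c2cncc(-c3cnn(C)c3)c2)ccc1C(N)=O` holds the highest number of the three measured compounds in an assay on cells for inhibition of MAP kinase-interacting serine/threonine-protein kinase 1 (Homo sapiens), read by mobility shift assay, with stated times of 10 min and 60 min, in the presence of a further agent that is not named here (on this read-out lower numbers stand for stronger inhibition and higher numbers for weaker inhibition), giving 400 nM; compound 1 `Cc1[nH]ncc1-c1cncc(-c2ccc(C(N)=O)c(OC(C)C)c2)c1` gives 54 nM and compound 2 `CC(C)Oc1cc(-c2cncc(-c3cnn(C(C)C)c3)c2)ccc1C(N)=O` gives 85 nM. The measured steps read a 1.6-fold higher number from compound 1 to compound 2 (0.20 log units; within the scatter), a 7.4-fold higher number from compound 1 to compound 3 (0.87 log units; beyond the scatter) and a 4.7-fold higher number from compound 2 to compound 3 (0.67 log units; beyond the scatter). Compound 4 `CC(C)Oc1cc(-c2cncc(-c3c[nH]nc3C3CC3)c2)ccc1C(N)=O` carries 3-cyclopropyl-1H-pyrazol-4-yl in place of 1-methyl-1H-pyrazol-4-yl on an aromatic carbon. Among the measured compounds shown here, both steps arriving at compound 3 bear on this change, as each moves away from compound 3 toward a lower number; compound 1 is the nearest measured neighbour to compound 4, and no step shows what the cyclopropyl adds. Compound 4 is therefore expected to show a 6.7-fold lower number from compound 3 to compound 4 (0.82 log units; beyond the scatter). Compound 4 is estimated at 60 nM, within 25 nM to 160 nM.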

Compound 4, half-maximal inhibitory concentration: 130 nM
Beside the measured number, compound 4's estimate is 2.2-fold (0.34 log units) below it; measured number inside the range.
By their numbers in this assay, from the lowest: compounds 1, 2 and 4 (each within the scatter of the next, the first and the last beyond it); then compound 3.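

In this assay, 3-cyclopropyl-1H-pyrazol-4-yl improves on 1-methyl-1H-pyrazol-4-yl, with a 3.1-fold lower number from compound 3 to compound 4 (0.49 log units; beyond the scatter). It cannot be separated from 1-isopropyl-1H-pyrazol-4-yl, with a 1.5-fold higher number from compound 2 to compound 4 (0.18 log units; within the scatter), but falls short of 5-methyl-1H-pyrazol-4-yl, with a 2.4-fold higher number from compound 1 to compound 4 (0.38 log units; beyond the scatter), so the larger carbon substituent on this pyrazole gives no gain over methyl. No measurement shown accounts for these differences. Still open, on these data alone, is how an amine or a longer alkyl chain in place of the cyclopropyl would read on this pyrazole.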